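One Stereocentre Redrawn at a Saturated Ring Carbon

A few compounds are considered here, and "the series" means these few. Any claim that something is new, unique, unknown or untested is made for them only; others in the source may bear on it.

In an ADME assay on Akata cells (Homo sapiens) for cytotoxicity (on this read-out lower numbers stand for higher toxicity in this test and higher numbers for lower toxicity in this test), compound 1 `Nc1nc2c(ncn2/C=C2\C[C@@H]2[C@H](O)CO)c(=O)[nH]1` gives 67000 nM. Among the measured compounds shown here, compound 2 `Nc1ncnc2c1ncn2/C=C1\C[C@@H]1[C@H](O)CO` gives 57000 nM, a value within the scatter of that of compound 1, so the two compounds stand level on the only numbers available. Compound 3 `Nc1nc2c(ncn2/C=C2\C[C@H]2[C@H](O)CO)c(=O)[nH]1` has yet to be measured. It has the same atoms and bonds as compound 1 and differs only in configuration as drawn (the two compounds have the same atoms and bonds and differ only in configuration as drawn: 1 of 3 stereo elements differ; a stereocentre at a saturated ring carbon is drawn S in compound 1 and R in compound 3): a stereocentre at a saturated ring carbon is drawn S in compound 1 and R in compound 3. For the measured compounds named here, no measured pair shows what such a difference does in this assay, so the data give no direction for the change, and no step beyond the scatter is expected. The estimated step is a 1.0-fold lower number from compound 1 to compound 3 (0.01 log units; within the scatter). For compound 3 the expected value is 65000 nM, with an estimated range from 30000 nM to 140000 nM.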

Compound 3, half-maximal cytotoxic concentration: 86600 nM
Estimate against measurement, compound 3: 1.3-fold (0.12 log units) below, within the range that was stated.
By their numbers in this assay, from the lowest: compounds 2, 1 and 3 (each within the scatter of the next).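

In this assay, redrawing the stereocentre at a saturated ring carbon from S to R gives a 1.3-fold higher number from compound 1 to compound 3 (0.11 log units; within the scatter). Among the compounds shown here, this is the first measured pair to show what such a difference does in this test, and at this one position it does not carry the read-out beyond the scatter. Any gap between the two compounds can be set against one thing alone: the fact that compounds 1 and 3 differ only in the configuration as drawn.

The compounds shown leave open whether the same redrawing would also stay within the scatter on compound 2, and what a change at either of the other two stereo elements would do. They also do not tell how the read-out would respond to an amine or a carboxylic acid in place of a hydroxyl group.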